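The source may hold more compounds than are shown below. What is called first, only, known or untested is meant among the compounds shown, and "the series" means these compounds.

Measured so far in an ADME assay on A549 cells (Homo sapiens) for cytotoxicity, read by LDH release, with a stated time of 15 h; on this read-out higher numbers stand for lower toxicity in this test and lower numbers for higher toxicity in this test
compound 1 `CCCN(CCC)c1ccc(NC(=O)c2cc(Cl)ccc2O)c(Cl)c1` gives 323000 nM
compound 2 `O=C(Nc1ccc(NCc2cc(C(F)(F)F)cc(C(F)(F)F)c2)cc1Cl)c1cc(Cl)ccc1O` gives 22900 nM
compound 3 `CC(C)(C)OC(=O)N1CCC(CNc2ccc(NC(=O)c3cc(Cl)ccc3O)c(Cl)c2)CC1` gives "not determined" (no result reported)

On these numbers compound 1 stands highest, with 323000 nM as the larger of only two figures, and compound 2 at 22900 nM lies beyond the scatter below it. Compound 3 offers no number for comparison. The step followed here leads from compound 1 to compound 4 `CC1(Nc2ccc(NC(=O)c3cc(Cl)ccc3O)c(Cl)c2)CCCCC1` and places (1-methylcyclohexyl)amino in place of dipropylamino on an aromatic carbon on the shared core. Among the compounds with values here, no measured pair differs in one place, so nothing directly sizes this change. Compound 1 already sits at the top of the range, and compound 2 at 22900 nM is the only lower reference, so a move down is expected, though probably not all the way to that figure. In this assay the expected change is a 4.6-fold lower number from compound 1 to compound 4 (0.66 log units; beyond the scatter) as an estimate, toward lower numbers and probably beyond the scatter. Compound 4 is estimated at 70000 nM with 18000 nM to 250000 nM as the expected range.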

Compound 4, half-maximal cytotoxic concentration: 86500 nM
Estimate against measurement, compound 4: 1.2-fold (0.09 log units) below; measured number inside the range.
By their numbers in this assay, from the lowest: compound 2; then compound 4; then compound 1.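

In this assay, within the data shown here, the step gives the first measure of a change at this position, on an aromatic carbon para to a large group and meta to a chloro group: placing (1-methylcyclohexyl)amino in place of dipropylamino gives a 3.7-fold lower number from compound 1 to compound 4 (0.57 log units; beyond the scatter). This single change brings in a six-membered non-aromatic ring of carbon only and a hydrogen-bond donor, and it also replaces a group without a ring, so the modest shift toward a lower number belongs to the exchange as a whole. No measurement presented here explains the shift.

The compounds shown leave open whether the ring, the nitrogen-bound hydrogen or the methyl group on the ring accounts for the step. Propylamino and cyclohexylamino at the same position would help to separate these features.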